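A few compounds are considered here, and "the series" means these few. Any claim that something is new, unique, unknown or untested is made for them only; others in the source may bear on it.

Compounds measured in a functional assay on CHO cells with adenosine receptor A1 (Homo sapiens) as the target, read by cAMP accumulation and immunoassay, with a stated time of 6 min, tested at 0.1 uM; a higher number here means a weaker effect of the compound at the concentration tested, a lower number a stronger effect:
- compound 1, `Nc1scc(CN2CCN(c3cccc(C(F)(F)F)c3)CC2)c1C(=O)c1ccc(Cl)cc1` — -30%
- compound 2, `Nc1scc(CN2CCN(c3cc(F)cc(F)c3)CC2)c1C(=O)c1ccc(Cl)cc1` — -5%

Compound 2 stands highest of the two numbers; its nearest neighbour is compound 1, and the step of a number 25 percentage points higher from compound 1 to compound 2 (beyond the scatter) is the only measured one. Compound 3, `Nc1scc(CN2CCN(c3cccc(Cl)c3)CC2)c1C(=O)c1ccc(Cl)cc1`, is not yet measured; it differs from compound 2 by 3-chlorophenyl in place of 3,5-difluorophenyl on an amine nitrogen in a ring. The measured step concerns the same place on the ring nitrogen, so a change of similar size is possible, with the 3-chlorophenyl expected to sit nearer compound 1. The step is expected to be a number 10 percentage points lower from compound 2 to compound 3 (within the scatter). Compound 3 is expected to give -15%, within -35% to 5%.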

Compound 3, a percentage reported as activity, at one concentration (the size of the read-out at that concentration, not a potency): -20%
Compound 3: the middle estimate sits 5 percentage points above what was measured, and the stated range covers the measured number.
By their numbers in this assay, from the lowest: compounds 1 and 3 (each within the scatter of the next); then compound 2.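

In this assay the 3-chlorophenyl on the amine nitrogen in the ring gives a number 15 percentage points lower from compound 2 to compound 3 (beyond the scatter), which sets the 3,5-difluorophenyl of compound 2 apart from both other aryl groups. For chloro in place of trifluoromethyl on an aromatic carbon, the change is a number 10 percentage points higher from compound 1 to compound 3 (within the scatter), so this position does not separate these two substituents in this assay. Nothing available accounts for these differences.

Open, as far as these compounds go, is where a 3-fluorophenyl, with one fluorine, would fall relative to compound 2 and compound 3. Also open, from the compounds shown here alone, is how a methoxy or a nitrile on the same phenyl ring would read.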